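The source may report more compounds than this note shows. Statements on the series, on what has been measured and on what is new or still open speak of the compounds shown alone.

Among the three compounds measured in a functional assay on HT-29 cells (Homo sapiens) for antiproliferative activity, read by sulforhodamine B assay, with a stated time of 48 h (a lower number here means a stronger inhibitor, a higher number a weaker inhibitor), compound 3 `CCNC(=O)Nc1ccc(S(=O)(=O)Oc2ccccc2I)cc1` gives the lowest number, 5300 nM. Compound 1 `CC(=O)Nc1ccc(S(=O)(=O)Oc2ccccc2I)cc1` gives 23000 nM and compound 2 `CC(C)C(=O)Nc1ccc(S(=O)(=O)Oc2ccccc2I)cc1` gives 13000 nM; the steps of a 4.3-fold lower number from compound 1 to compound 3 (0.64 log units; beyond the scatter) and a 2.5-fold lower number from compound 2 to compound 3 (0.39 log units; beyond the scatter) both lie beyond the scatter. Compound 4 `CCCNC(=O)Nc1ccc(S(=O)(=O)Oc2ccccc2I)cc1` differs from compound 3 by methyl in place of hydrogen on a saturated chain carbon, two bonds along the chain from an amide-type nitrogen. Going by the values given here, the only measured step that grows a saturated chain is a 1.8-fold lower number from compound 1 to compound 2 (0.25 log units; within the scatter), which stays within the scatter; the steps to compound 3 exchange an amide for a urea and do not bear on chain length. A change of no more than the scatter in this assay is therefore expected, and for compound 4 the estimate is 4500 nM, in the range 2000 nM to 11000 nM, meaning an expected step of a 1.2-fold lower number from compound 3 to compound 4 (0.07 log units; within the scatter).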

Compound 4, half-maximal inhibitory concentration: 6800 nM
Beside the measured number, compound 4's estimate is 1.5-fold (0.18 log units) below it; low and high end bracket the measured number.
By their numbers in this assay, from the lowest: compounds 3, 4, 2 and 1 (each within the scatter of the next, the first and the last beyond it).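

Methyl in place of hydrogen on this saturated chain carbon, turning ethylamino into propylamino, leaves the number within the scatter (a 1.3-fold higher number from compound 3 to compound 4 (0.11 log units; within the scatter)). With propylamino on the carbonyl carbon, the comparison with methyl stays beyond the scatter (a 3.4-fold lower number from compound 1 to compound 4 (0.53 log units; beyond the scatter)), while the comparison with isopropyl falls within it (a 1.9-fold lower number from compound 2 to compound 4 (0.28 log units; within the scatter)), unlike that of ethylamino. Nothing shown explains these steps. From the compounds shown here alone, whether a longer chain such as butylamino would move the number beyond the scatter remains open. So does the effect of a branched isopropylamino group or a terminal amine on the chain.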